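The compounds below may be only part of what the source reports. "The series", "measured", "known", "first", "only" and "open" are said of these compounds alone.

Compound 1 `COc1ccc2c(=O)c(/C=C/C(=O)Nc3cc(C)ccc3C)coc2c1` gives 11100 nM.
Compound 2 `COc1cccc(NC(=O)/C=C/c2coc3cc(OC)ccc3c2=O)c1` gives 11100 nM.
Compound 3 `COc1ccc2c(=O)c(/C=C/C(=O)NCc3ccc(F)cc3)coc2c1` gives 21000 nM.

In a functional assay on Huh-7 cells (Homo sapiens) for inhibition, read by MTT assay, with a stated time of 48 h (on this read-out lower numbers stand for stronger inhibition and higher numbers for weaker inhibition), compound 3 holds the highest of the three numbers, yet the steps of a 1.9-fold higher number from compound 1 to compound 3 (0.28 log units; within the scatter) and a 1.9-fold higher number from compound 2 to compound 3 (0.28 log units; within the scatter) both stay within the scatter, so no order among the three can be claimed. Compound 4 `COc1ccc(CNC(=O)/C=C/c2coc3cc(OC)ccc3c2=O)cc1` differs from compound 3 by methoxy in place of fluoro on an aromatic carbon. Going by the values given here, no measured step touches this position; the steps of no change at the digits printed from compound 1 to compound 2 (within the scatter) and a 1.9-fold higher number from compound 2 to compound 3 (0.28 log units; within the scatter) swap the whole group on the amide nitrogen and all remained within the scatter, which suggests this part of the molecule tolerates change. The step of a 1.1-fold lower number from compound 3 to compound 4 (0.02 log units; within the scatter) is therefore expected to stay within the scatter. Compound 4 is estimated at 20000 nM, between 8000 nM and 50000 nM.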

Compound 4, half-maximal inhibitory concentration: 7570 nM
The estimate for compound 4 lay 2.6-fold (0.42 log units) above the measured number, outside the stated range (below it).
By their numbers in this assay, from the lowest: compounds 4, 1, 2 and 3 (each within the scatter of the next, the first and the last beyond it).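

In this assay, going by these compounds alone, the first change at the aromatic carbon para to a large group, methoxy in place of fluoro, gives a modest step beyond the scatter (a 2.8-fold lower number from compound 3 to compound 4 (0.44 log units; beyond the scatter)), so a small change at this position can matter. Replacing the whole group on the amide nitrogen still leaves compound 4 within the scatter of both other compounds (a 1.5-fold lower number from compound 2 to compound 4 (0.17 log units; within the scatter); a 1.5-fold lower number from compound 1 to compound 4 (0.17 log units; within the scatter)). Nothing available explains the step.

With only fluoro and methoxy shown at this position, how an amine, a hydroxyl or a longer chain such as ethoxy would read remains open. Also open, on these data alone, is whether the same change would give a similar step on another group on the amide nitrogen.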